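The source may report more compounds than this note shows. Statements on the series, on what has been measured and on what is new or still open speak of the compounds shown alone.

Compound 1 `Cc1ccc(C(=O)N(C(=S)OCCN2C(=O)c3ccccc3C2=O)c2ccc(Cl)cc2)cc1` sits at the limit of an ADME assay on MT4 cells (Homo sapiens) for cytotoxicity, read by MTT assay; on this read-out higher numbers stand for lower toxicity in this test and lower numbers for higher toxicity in this test: in this assay compound 1 gives > 100000 nM, a limit rather than a number. Compound 2 `O=C1c2ccccc2C(=O)N1CCOC(=S)N(C(=O)c1ccc(Cl)cc1Cl)c1ccc(Cl)cc1` gives 18000 nM in this assay. Within the data shown here, the single measured step, an at least 5.5-fold lower number from compound 1 to compound 2 (0.74 log units; beyond the scatter), is known only as a bound because of the limit of > 100000 nM in this assay, at which 1 of the 2 values shown sits.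

Compound 3 `Cc1cc(C(=O)N(C(=S)OCCN2C(=O)c3ccccc3C2=O)c2ccc(Cl)cc2)ccc1Br` differs from compound 1 by 4-bromo-3-methylphenyl in place of 4-methylphenyl on a carbonyl carbon. Among the measured compounds shown here, no measured step matches this change; the halogenation step from compound 1 to compound 2 is the nearest guide, so a downward step of smaller size is expected, an at least 1.6-fold lower number from compound 1 to compound 3 (0.22 log units; that floor lies within the scatter). Compound 3 is estimated at 60000 nM, expected to fall between 20000 nM and 150000 nM.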

Compound 3, half-maximal cytotoxic concentration: 18000 nM
The estimate for compound 3 lay 3.3-fold (0.52 log units) above the measured number, outside the stated range (below it).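

With 4-bromo-3-methylphenyl on the carbonyl carbon, this assay shows an at least 5.5-fold lower number from compound 1 to compound 3 (0.74 log units; beyond the scatter), so 2,4-dichlorophenyl is not the only replacement for 4-methylphenyl that goes with a lower number. The two replacements give no change at the digits printed from compound 2 to compound 3 (within the scatter). Both steps from compound 1 are bounds, not sizes, because of the assay limit: the limit of > 100000 nM in this assay, at which 1 of the 3 values shown sits.

Open, from the compounds shown here alone, is whether bromine alone accounts for the step, which a 4-bromophenyl group on the same carbonyl carbon would test. Also open, going by these compounds, is whether a halogen is needed at all, which a 4-methoxyphenyl group would test.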